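This account rests on a few compounds, and the source may have more. Where it says the series, first, only, none or still open, it means among the compounds named here.

Compounds measured in a functional assay on A549 cells (Homo sapiens) for cytotoxicity, read by MTT assay, with a stated time of 72 h; a lower number here means a stronger inhibitor, a higher number a weaker inhibitor:

- compound 1, `CN(C)CCn1cnnc1-c1cc(Oc2ccc(NC(=O)N/N=C/c3ccc(O)c(Br)c3)cc2F)ccn1`: 1370 nM
- compound 2, `CN(C)CCn1cnnc1-c1cc(Oc2ccc(NC(=O)N/N=C/c3ccccc3)cc2F)ccn1`: 1860 nM
- compound 3, `CN(C)CCn1cnnc1-c1cc(Oc2ccc(NC(=O)N/N=C/c3ccc(F)cc3)cc2F)ccn1`: 1790 nM

All three share the same core and differ only in the aryl group on a carbon with a double bond to nitrogen. Compound 3 gives the second highest of the three numbers, but its neighbours lie close: the step of a 1.0-fold lower number from compound 2 to compound 3 (0.02 log units; within the scatter) and the step of a 1.3-fold higher number from compound 1 to compound 3 (0.12 log units; within the scatter) are both within the scatter, so no order among the three can be claimed.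

Compound 4, `CN(C)CCn1cnnc1-c1cc(Oc2ccc(NC(=O)N/N=C/c3cc(Br)c(O)c(Br)c3)cc2F)ccn1`, has not yet been measured. It differs from compound 3 in one place: 3,5-dibromo-4-hydroxyphenyl in place of 4-fluorophenyl on a carbon with a double bond to nitrogen. Among the measured compounds shown here, two measured steps bear on this change. The step of a 1.3-fold higher number from compound 1 to compound 3 (0.12 log units; within the scatter) and the step of a 1.4-fold higher number from compound 1 to compound 2 (0.13 log units; within the scatter) show that exchanging a 3-bromo-4-hydroxyphenyl for a phenyl or a 4-fluorophenyl moved this assay by less than the scatter. For the measured compounds named here, no measured pair shows the effect of a second bromine on that ring, so only the reverse of the step from compound 1 to compound 3 can guide the expectation. The step of a 1.4-fold lower number from compound 3 to compound 4 (0.14 log units; within the scatter) is therefore expected to be small, leaning slightly toward a lower number. Compound 4 is estimated at 1300 nM, within a range from 500 nM to 3500 nM.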

Compound 4, half-maximal inhibitory concentration: > 100000 nM
Compound 4: only a limit was reported; the forecaster's own chance of this, stated with the estimate: 5%; middle value at least 76-fold (1.88 log units) away from the limit.
By their numbers in this assay, from the lowest: compounds 1, 3 and 2 (each within the scatter of the next). At a limit, above all of these: compound 4.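

The aryl group on this carbon looked forgiving among compounds 1, 2 and 3, but it is not: in this assay, adding one more bromine to the ring gives an at least 72-fold higher number from compound 1 to compound 4 (1.86 log units; beyond the scatter). Replacing the whole aryl group shows a change of similar size, with an at least 55-fold higher number from compound 3 to compound 4 (1.74 log units; beyond the scatter) and an at least 53-fold higher number from compound 2 to compound 4 (1.73 log units; beyond the scatter), so the 3,5-dibromo-4-hydroxyphenyl group stands apart from the other three groups. Compound 4 is reported only as a limit, so the true size of these steps remains unknown: the limit of > 100000 nM in this assay, at which 1 of the 4 values shown sits.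

The compounds shown leave open whether a chlorine or a methyl group in place of the second bromine would have the same effect. They also leave open what a methoxy group in place of the hydroxyl would do with both bromines present.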